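Shared core series: aryl exchange on the amide nitrogen

The compounds below may be only part of what the source reports. "The series", "measured", "known", "first", "only" and "open" are said of these compounds alone.

The three measured compounds share one core and differ only in the heteroaryl group on the saturated chain carbon bound to the amide-type nitrogen. Compound 1 `COC(=O)c1ccc(N(Cc2ccc(C3CCCCC3)nc2)C(=O)[C@H]2CCN2S(=O)(=O)c2c(F)c(F)c(F)c(F)c2F)cc1O` gives 2000 nM in a functional assay on MDA-MB-231 cells (Homo sapiens) for antiproliferative activity, with a stated time of 72 h; a higher number here means that more compound is needed for the effect, a lower number that less compound is needed. Compound 2 `COC(=O)c1ccc(N(Cc2ccc(C3CCCCC3)cn2)C(=O)[C@H]2CCN2S(=O)(=O)c2c(F)c(F)c(F)c(F)c2F)cc1O` gives 1800 nM, and compound 3 `COC(=O)c1ccc(N(Cc2cnc(C3CCCCC3)cn2)C(=O)[C@H]2CCN2S(=O)(=O)c2c(F)c(F)c(F)c(F)c2F)cc1O` gives 1600 nM. Compound 3 carries the smallest number shown, yet no compound separates from the others: a 1.3-fold lower number from compound 1 to compound 3 (0.10 log units; within the scatter), a 1.1-fold lower number from compound 2 to compound 3 (0.05 log units; within the scatter), and a 1.1-fold lower number from compound 1 to compound 2 (0.05 log units; within the scatter) all lie within the scatter, so the three heteroaryl variants behave alike.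

Compound 4 `O=C([C@H]1CCN1S(=O)(=O)c1c(F)c(F)c(F)c(F)c1F)N(Cc1cnc(C2CCCCC2)cn1)c1ccc2nn[nH]c2c1` keeps the heteroaryl group of compound 3 and alters the other substituent on the amide-type nitrogen: a group of 9 heavy atoms (6 carbon, 3 nitrogen; one five-membered aromatic ring with 3 hetero atoms, one six-membered aromatic ring of carbon only) in place of a group of 11 heavy atoms (8 carbon, 3 oxygen; one six-membered aromatic ring of carbon only), on an amide-type nitrogen. For the measured compounds named here, none of the measured steps touches this position, so nothing among the recorded numbers bears directly on the change; the only anchor is the flat response of this assay to the variations so far. In this assay compound 4 is therefore expected to stay near compound 3, with a wide range, the estimated step being no change at the digits printed from compound 3 to compound 4 (within the scatter). Compound 4 is estimated at 1600 nM, between 400 nM and 6500 nM.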

Compound 4, half-maximal effective concentration: 2100 nM
Compound 4: the middle estimate sits 1.3-fold (0.12 log units) below what was measured, and the stated range covers the measured number.
By their numbers in this assay, from the lowest: compounds 3, 2, 1 and 4 (each within the scatter of the next).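

In this assay the other substituent on the amide-type nitrogen now has a reading of its own: the group of 9 heavy atoms in place of 3-hydroxy-4-(methoxycarbonyl)phenyl gives a 1.3-fold higher number from compound 3 to compound 4 (0.12 log units; within the scatter) in a compound that keeps 5-cyclohexylpyrazin-2-yl. For the compounds shown here, the earlier compounds varied only the heteroaryl group, so this is the first sign that the flat response also extends to this second position, and that with this heteroaryl group the 3-hydroxy-4-(methoxycarbonyl)phenyl group is not required to stay in the same range. No supporting data bear on why this exchange leaves the value within the scatter.

On these data alone, all four compounds sit in one narrow band, so what would move the number at either position remains open. Also open, as far as these compounds go, is how a carboxylic acid in place of the methoxycarbonyl group, or an amine in place of the cyclohexyl group, would read.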